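Compound 3 to compound 4, near the assay limit

The compounds below may be only part of what the source reports. "The series", "measured", "known", "first", "only" and "open" are said of these compounds alone.

Measured in a functional assay on U-87MG ATCC cells for antiproliferative activity against U-87 MG (Homo sapiens), read by spectrophotometry, with a stated time of 2 days; on this read-out lower numbers stand for stronger inhibition of growth and higher numbers for weaker inhibition of growth:
- compound 1 `COc1ccc(Nc2ncc(C(F)(F)F)c(N3Cc4cccc(N(C)S(C)(=O)=O)c4C3)n2)cc1C(F)(F)F`: 29400 nM
- compound 2 `CC(=O)N1CCN(c2ccc(Nc3ncc(C(F)(F)F)c(N4Cc5cccc(N(C)S(C)(=O)=O)c5C4)n3)cc2)CC1`: 22100 nM
- compound 3 `CN(c1cccc2c1CN(c1nc(Nc3ccc(C(F)(F)F)cc3)ncc1C(F)(F)F)C2)S(C)(=O)=O`: > 30000 nM, a limit of the assay and not a number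

Compound 3 has no exact value, so its position is known only as the limit of > 30000 nM in this assay, at which 1 of the 3 values shown sits. The next compound, compound 4 `CN(c1cccc2c1CN(c1nc(Nc3ccc(Cl)c(C(F)(F)F)c3)ncc1C(F)(F)F)C2)S(C)(=O)=O`, keeps the shared core and replaces 4-(trifluoromethyl)phenyl with 4-chloro-3-(trifluoromethyl)phenyl on a nitrogen on an aromatic ring (4-chloro-3-(trifluoromethyl)phenyl in place of 4-(trifluoromethyl)phenyl on a nitrogen on an aromatic ring).

For the measured compounds named here, two measured steps bear on this change. The closer one is an at least 1.0-fold higher number from compound 1 to compound 3 (0.00 log units; that floor lies within the scatter), since it alters the group on that same nitrogen. The other, an at least 1.3-fold higher number from compound 2 to compound 3 (0.13 log units; that floor lies within the scatter), replaces 4-acetylpiperazin-1-yl with trifluoromethyl on an aromatic carbon. Both are only floors that lie within the scatter, so neither shows that changing this group moves the read-out in this assay. No step beyond the scatter is therefore expected, and no direction can be relied on. The estimate corresponds to an expected at least 1.2-fold lower number from compound 3 to compound 4 (0.09 log units; that floor lies within the scatter). Compound 4 is expected to give about 24000 nM, with an estimated range of 10000 nM to 30000 nM.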

Compound 4, concentration for 50% growth inhibition: > 30000 nM
Compound 4 was reported as a limit; the forecaster's own chance of this, stated with the estimate: 40%; middle value at least 1.2-fold (0.09 log units) away from the limit.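

Compound 4 is reported in this assay as > 30000 nM, which is a limit of the assay and not a number. Compound 3 is also recorded only as a limit, so the step from 4-(trifluoromethyl)phenyl to 4-chloro-3-(trifluoromethyl)phenyl cannot be read, and this position gains a second group whose effect on the read-out stays hidden. The one comparison that yields a size, chloro in place of methoxy on an aromatic carbon, gives an at least 1.0-fold higher number from compound 1 to compound 4 (0.00 log units; that floor lies within the scatter), so this change on the same ring shows no shift beyond the scatter, and the series now has more of its values at the edge of what the assay can report: the limit of > 30000 nM in this assay, at which 2 of the 4 values shown sit.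

The compounds shown leave open whether any group on this nitrogen can bring growth inhibition clearly away from that limit, and how far the chloro and the added trifluoromethyl each contribute on their own. A phenyl ring carrying a carboxylic acid or a primary amine would test a different kind of substituent at this position, one unlike the groups seen here.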